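Removing a Methyl from an Aromatic Nitrogen

This account rests on a few compounds, and the source may have more. Where it says the series, first, only, none or still open, it means among the compounds named here.

Measured compounds:
Compound 1 `Cn1cc(-c2nn(C)c3cc(N)ccc23)cn1` gives > 384000 nM.
Compound 2 `Cn1cc(-c2n[nH]c3cc(Cl)c(Br)cc23)cn1` gives 850 nM.
Compound 3 `Nc1ccc2c(-c3cccnc3)n[nH]c2c1` gives 28400 nM.

All three were tested in an assay on isolated protein for inhibition of tyrosine-protein kinase receptor UFO (Homo sapiens), with a stated time of 1.5 h; on this read-out lower numbers stand for stronger inhibition and higher numbers for weaker inhibition. Compound 1 yields no number at all, only a limit of the assay, as recorded in the limit of > 384000 nM in this assay, at which 1 of the 3 values shown sits, so no inhibition could be quantified for it. Compound 2 gives 850 nM, and compound 3 gives 28400 nM; both carry a hydrogen rather than a methyl on the shared core, and both return real numbers.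

Compound 4 `Cn1cc(-c2n[nH]c3cc(N)ccc23)cn1` has not yet been measured. It differs from compound 1 by hydrogen in place of methyl on an aromatic nitrogen. Among the compounds with values here, since compound 1 sits at a limit, no step between measured compounds fixes the size of this change, but the numbers for compound 2 and compound 3 show that the unmethylated core can give a measurable value. The change is therefore expected to move compound 4 toward stronger inhibition, as a step of an at least 19-fold lower number from compound 1 to compound 4 (1.28 log units; beyond the scatter). Compound 4 is estimated at 20000 nM, within a range of 3000 nM to 150000 nM.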

Compound 4, half-maximal inhibitory concentration: 28800 nM
Compound 4: middle estimate off by 1.4-fold (0.16 log units), on the low side; the range from low to high includes it.
By their numbers in this assay, from the lowest: compound 2; then compounds 3 and 4 (each within the scatter of the next). At a limit, above all of these: compound 1.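

In this assay, within the data shown here, putting hydrogen in place of the methyl on the aromatic nitrogen gives an at least 13-fold lower number from compound 1 to compound 4 (1.12 log units; beyond the scatter) and so provides the first direct reading of this change within a single pair of compounds. Nothing else differs between the two, so this one nitrogen alone separates a compound with no quantifiable inhibition from one with a real number. The step has only a lower bound, and its true size stays unknown, since compound 1 is recorded only as a limit: the limit of > 384000 nM in this assay, at which 1 of the 4 values shown sits.

The compounds shown leave open whether this nitrogen accepts anything other than hydrogen or methyl, such as an ethyl group or a longer chain. They also leave open whether the same change would act alike on a core carrying other groups, such as the chlorine and bromine of compound 2.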